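Hydroxyphenyl Ether Replaces Trifluoromethylphenyl in Weak Inhibitor Series

The source may report more compounds than this note shows. Statements on the series, on what has been measured and on what is new or still open speak of the compounds shown alone.

Of the compounds shown here, two have been measured in an assay on SH-SY5Y cells for inhibition of Voltage-dependent N-type calcium channel subunit alpha-1B (Homo sapiens), read by FLIPR and calcium flux, with stated times of 600 s and 300 s, in the presence of a further agent that is not named here; a lower number here means a stronger inhibitor, a higher number a weaker inhibitor. Compound 1 `CN(C)CCCOc1ccc(CN(C)c2nc3ccc(Oc4ccc(C(F)(F)F)cc4)cc3s2)cc1` gives 46000 nM in this assay. Compound 2 `NCCCOc1ccc(CNc2nc3ccc(Oc4cccc(C(F)(F)F)c4)cc3s2)cc1` gives 144000 nM in this assay, the higher of the two numbers, and the gap to compound 1 lies beyond the usual scatter, so compound 2 is the weaker inhibitor of the pair. Going by the values given here, no pair of measured compounds differs in a single place, so the two values can only be set side by side, and no single structural change has yet been tied to a shift in this assay.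

Compound 3 `NCCCOc1ccc(CNc2nc3ccc(Oc4ccc(O)cc4)cc3s2)cc1` has not been measured. It differs from compound 2 in one place: 4-hydroxyphenyl in place of 3-(trifluoromethyl)phenyl on an oxygen on an aromatic ring. Among the compounds with values here, no measured compound carries a 4-hydroxyphenyl group, so this change has no counterpart in the data. Given that compound 2 already gives 144000 nM, the expectation is that the number stays roughly where it is or rises. The step is expected to read a 1.4-fold higher number from compound 2 to compound 3 (0.14 log units; within the scatter) in this assay. Compound 3 is estimated at 200000 nM, with a range from 60000 nM to 600000 nM.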

Compound 3, half-maximal inhibitory concentration: 205000 nM
For compound 3 the middle estimate is 1.0-fold (0.01 log units) below the measured one, and the stated range covers the measured number.
By their numbers in this assay, from the lowest: compound 1; then compounds 2 and 3 (each within the scatter of the next).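

Going by these compounds alone, replacing 3-(trifluoromethyl)phenyl with 4-hydroxyphenyl on an oxygen on an aromatic ring gives the first comparison that differs in one place, and in this assay it reads as a 1.4-fold higher number from compound 2 to compound 3 (0.15 log units; within the scatter). The position therefore accepts this exchange without a shift that can be told from the scatter, even though the entering group brings a hydrogen-bond donor and a hydrogen-bond acceptor that the leaving group lacks and has fewer heavy atoms. No measurement shown here bears on why the two compounds read alike, and the step alone gives no explanation.

Because the exchange alters both the group and where its substituent stands on the ring, the compounds shown cannot separate the effect of 4-hydroxyphenyl from that of moving away from the 3-substituted pattern, and compound 1 differs from compound 2 in more than one place, so the source of their gap stays unassigned. On these data alone, it also remains open whether an amine, a carboxylic acid or a longer chain on this phenyl ring would give a number beyond the scatter of compound 2 in either direction.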